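Swapping a benzylamine for a thioether on a shared core

The source may hold more compounds than are shown below. What is called first, only, known or untested is meant among the compounds shown, and "the series" means these compounds.

Of the compounds shown here, three built on one shared core have been tested in a functional assay on CAKI-1 cells (Homo sapiens) for inhibition, read by sulforhodamine B assay, with a stated time of 48 h; a lower number here means a stronger inhibitor of growth, a higher number a weaker inhibitor of growth. Compound 1, `Nc1cc(N)c2nc(-c3ccccc3)c(Oc3ccc(Cl)c(Cl)c3)nc2c1`, gives only a limit of < 100000 nM in this assay, not a number. Compound 2, `Nc1cc(N)c2nc(-c3ccccc3)c(NCc3ccc(F)cc3)nc2c1`, gives 37200 nM in this assay. Compound 3, `COc1ccc(CNc2nc3cc(N)cc(N)c3nc2-c2ccccc2)cc1`, gives 36300 nM in this assay. The step that the limit leaves unreadable from compound 1 to compound 2 cannot be read in size because compound 1 sits at the limit (the limit of < 100000 nM in this assay, at which 1 of the 3 values shown sits). The step of a 1.0-fold lower number from compound 2 to compound 3 (0.01 log units; within the scatter) lies within the scatter. Compound 2 therefore holds the highest of the two numbers recorded, with compound 3 within the scatter of it, and the remaining value being only a limit.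

Compound 4, `COc1ccc(Sc2nc3cc(N)cc(N)c3nc2-c2ccccc2)cc1`, differs from compound 2 by (4-methoxyphenyl)sulfanyl in place of (4-fluorobenzyl)amino on an aromatic carbon. For the measured compounds named here, two measured steps bear on this change. The step that the limit leaves unreadable from compound 1 to compound 2 exchanged the whole group at this position but its size stays unreadable. The step of a 1.0-fold lower number from compound 2 to compound 3 (0.01 log units; within the scatter) altered only the outer part of the same group and stayed within the scatter. The replacement in compound 4 is larger than that, so the expectation is uncertain. Compound 4 is expected to give about 40000 nM, within a range from 12000 nM to 100000 nM. The estimated step of a 1.1-fold higher number from compound 2 to compound 4 (0.03 log units; within the scatter) is expected to remain small.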

Compound 4, concentration for total growth inhibition: 52500 nM
The estimate for compound 4 lay 1.3-fold (0.12 log units) below the measured number, within the range that was stated.
By their numbers in this assay, from the lowest: compounds 3, 2 and 4 (each within the scatter of the next).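

In this assay, putting (4-methoxyphenyl)sulfanyl in place of (4-fluorobenzyl)amino gives a 1.4-fold higher number from compound 2 to compound 4 (0.15 log units; within the scatter). Until now, the only readable change at this position touched just the outer end of the group, whereas here the whole group is exchanged: the hydrogen-bond donors go from 1 to 0 and the hydrogen-bond acceptors from 1 to 2, yet the number stays within the scatter, so among these compounds this exchange leaves no readable mark on growth inhibition. Compound 1 gives only a limit, so neither step involving it can be read, and how the 3,4-dichlorophenoxy group compares with the other groups stays unknown: the limit of < 100000 nM in this assay, at which 1 of the 4 values shown sits.

From the compounds shown here alone, every readable number here lies within the scatter of the others, so it remains open whether any group at this position can move the number beyond that scatter, for example a carboxylic acid, a simple dimethylamine, or a longer chain between the shared core and the aromatic ring. Going by these compounds, it is also open whether changing the phenyl group on the shared core would matter more than changing this position.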